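The source may hold more compounds than are shown below. What is called first, only, known or untested is meant among the compounds shown, and "the series" means these compounds.

Of the compounds shown here, three built on one shared core have been measured in a physicochemical assay on HT-29 cells for lipophilicity; on this read-out lower numbers stand for lower lipophilicity and higher numbers for higher lipophilicity. Compound 1, `CS(=O)(=O)c1cccc2c1[n+]([O-])nc(N)[n+]2[O-]`, gives -1.38. Compound 2, `Nc1n[n+]([O-])c2cccc(Cl)c2[n+]1[O-]`, gives -0.102. Compound 3, `Cc1ccc2c(c1)[n+]([O-])c(N)n[n+]2[O-]`, gives 0.068. Among these three numbers compound 1 stands lowest: compound 2 lies nearest, its number higher by an amount beyond the usual scatter, and compound 3 lies furthest, also beyond the scatter.

Compound 4, `Nc1n[n+]([O-])c2c(Cl)cccc2[n+]1[O-]`, has not yet been measured in this assay. It differs from compound 1 in one place: chloro in place of methylsulfonyl on an aromatic carbon. Within the data shown here, no pair of measured compounds that differ in just one place is available, so the size of this step cannot be read off from a measured example and can only be expected. The other measured compounds both sit well above compound 1, which points toward a rise. A clear upward step, well beyond the scatter, is expected, namely a number 1.28 log units higher from compound 1 to compound 4 (beyond the scatter). Compound 4 is therefore estimated at -0.1, with a range from -0.6 to 0.4.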

Compound 4, partition coefficient: 0.166
Estimate against measurement, compound 4: 0.27 log units below; the range from low to high includes it.
By their numbers in this assay, from the lowest: compound 1; then compounds 2, 3 and 4 (each within the scatter of the next).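

In this assay, among these compounds, chloro in place of methylsulfonyl on this aromatic carbon gives a number 1.55 log units higher from compound 1 to compound 4 (beyond the scatter), the first step in this set that can be tied to a change in one place alone. The earlier compounds shown here could only hint at a rise, whereas this pair shows that the group at this position, ortho to a fused ring, can by itself move the read-out by a large amount, with a single chlorine atom replacing a larger group that carries hydrogen-bond acceptors. Nothing shown here gives an independent measurement that explains the size of this step.

From the compounds shown here alone, it remains open where other groups at this carbon, such as an amine or a carboxylic acid, would fall relative to chloro and methylsulfonyl. Going by these compounds, it is also open whether the same swap on another aromatic carbon of the shared core would give a step of similar size.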